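The source may hold more compounds than are shown below. What is called first, only, known or untested is meant among the compounds shown, and "the series" means these compounds.

Compound 1, `O=C(CSC(=S)N[C@H]1CCOC1=O)Nc1cccc(Cl)c1`, gives 46600 nM in a functional assay on MCF7 cells (Homo sapiens) for cytotoxicity, read by MTT assay, with a stated time of 72 h; on this read-out higher numbers stand for weaker inhibition and lower numbers for stronger inhibition. Compound 2, `O=C(CSC(=S)N[C@H]1CCOC1=O)Nc1ccccc1`, reaches only the limit > 128000 nM in this assay, so no number is known for it. Compound 3, `O=C(CCl)Nc1ccc(C(=O)/C=C/c2ccc(Cl)cc2)cc1`, gives 4100 nM in this assay.

Compound 1 and compound 2 share a core and differ in one place: hydrogen in place of chloro on an aromatic carbon. The result is an at least 2.7-fold higher number from compound 1 to compound 2 (0.43 log units; beyond the scatter), a step that can only be given as a lower bound because compound 2 sits at the limit of > 128000 nM in this assay, at which 1 of the 3 values shown sits.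

Compound 4, `O=C(CCl)Nc1ccc(C(=O)/C=C/c2ccccc2)cc1`, is not yet measured. It is built from compound 3 by the same kind of change: hydrogen in place of chloro on an aromatic carbon. The surroundings are not identical, though: in compound 1 the chloro sits meta to a large group, whereas in compound 3 it sits para to a large group. How the core of compound 3 differs from the core of compound 1 is not broken down here.

Within this small set, removing the chloro has so far weakened the cytotoxic effect, as the one measured example shows, and compound 3 is the lowest of the two numbers known. On that basis the step from compound 3 to compound 4 in this assay is expected to be a 2.4-fold higher number from compound 3 to compound 4 (0.39 log units; beyond the scatter), somewhat smaller than the measured one, since the placement around the removed chloro is not the same. Compound 4 is therefore estimated at 10000 nM, between 4000 nM and 30000 nM.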

Compound 4, half-maximal inhibitory concentration: 2480 nM
Estimate against measurement, compound 4: 4.0-fold (0.61 log units) above, and the stated range ends above it.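

On the core of compound 3, replacing the chloro with hydrogen in this assay gives a 1.7-fold lower number from compound 3 to compound 4 (0.22 log units; within the scatter), so the 4-chlorophenyl and phenyl versions cannot be told apart on this read-out. The same replacement therefore does not carry over with the same result from one core to the other, and the two steps differ by more than the scatter allows: the same change on two cores in this assay, an at least 2.7-fold higher number (0.43 log units; beyond the scatter) from compound 1 to compound 2 and a 1.7-fold lower number (0.22 log units; within the scatter) from compound 3 to compound 4, at least 4.5-fold (0.65 log units) apart, beyond the scatter of two such steps

This shows that, for these two pairs, the outcome of the replacement depends on its surroundings, but with only one pair per core it does not show which difference between the surroundings matters, nor how large the earlier step really is, as compound 2 gives only a limit and not a number: the limit of > 128000 nM in this assay, at which 1 of the 4 values shown sits.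

The compounds shown leave open whether the core of compound 3 is equally indifferent to other groups in that place on the phenyl ring, such as fluoro, bromo, methoxy or an amine. They also leave open how the same groups would behave on the core of compound 1, where a wider set of pairs could show whether the two cores truly follow separate trends.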